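The source may report more compounds than this note shows. Statements on the series, on what has been measured and on what is new or still open speak of the compounds shown alone.

Of the compounds shown here, three built on one shared core have been tested in a functional assay on HeLa cells (Homo sapiens) for inhibition; on this read-out higher numbers stand for weaker inhibition and lower numbers for stronger inhibition. Compound 1 `Oc1cccc(-c2cc(-c3cccc(F)c3)cc(-c3ccccc3O)n2)c1` reaches only the limit of the assay, > 50000 nM, so its true value is not known. Compound 2 `Oc1cccc(-c2cc(-c3cccc(F)c3)cc(-c3cccc(O)c3)n2)c1` gives 1400 nM in this assay. Compound 3 `Oc1cccc(-c2cc(-c3cccc(OC(F)(F)F)c3)cc(-c3ccccc3O)n2)c1` gives 14900 nM, a higher number than compound 2.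

The change from compound 1 to compound 2 is 3-hydroxyphenyl in place of 2-hydroxyphenyl on an aromatic carbon, and it brings an at least 35-fold lower number from compound 1 to compound 2 (1.55 log units; beyond the scatter); because compound 1 sits at the limit of > 50000 nM in this assay, at which 1 of the 3 values shown sits, the full size of that step cannot be known. The cores of compound 1 and compound 3 differ by trifluoromethoxy in place of fluoro on an aromatic carbon, which brings an at least 3.3-fold lower number from compound 1 to compound 3 (0.52 log units; beyond the scatter).

Compound 4 `Oc1cccc(-c2cc(-c3cccc(OC(F)(F)F)c3)cc(-c3cccc(O)c3)n2)c1` has not yet been measured. It differs from compound 3 by 3-hydroxyphenyl in place of 2-hydroxyphenyl on an aromatic carbon. This is the same kind of change as that from compound 1 to compound 2, though the surroundings differ: in compound 1 the place is meta to a 3-fluorophenyl group, in compound 3 it is meta to a large group. The expectation rests on compound 3 at 14900 nM and on an at least 35-fold lower number from compound 1 to compound 2 (1.55 log units; beyond the scatter). Compound 4 is therefore expected to show 800 nM in this assay, probably between 200 nM and 4000 nM. That estimate would mean a 19-fold lower number from compound 3 to compound 4 (1.27 log units; beyond the scatter).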

Compound 4, half-maximal inhibitory concentration: > 50000 nM
Compound 4 gave a limit, no number; the forecaster's own chance of this, stated with the estimate: 5%; middle value at least 62-fold (1.79 log units) from the limit.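

In this assay, the swap of 2-hydroxyphenyl for 3-hydroxyphenyl does not carry from one core to the other: where the trifluoromethoxy group is present it gives an at least 3.3-fold higher number from compound 3 to compound 4 (0.52 log units; beyond the scatter), the opposite direction to the step seen where the fluoro group is present: the same change on two cores in this assay, an at least 35-fold lower number (1.55 log units; beyond the scatter) from compound 1 to compound 2 and an at least 3.3-fold higher number (0.52 log units; beyond the scatter) from compound 3 to compound 4, at least 110-fold (2.07 log units) apart, beyond the scatter of two such steps Read the other way, trifluoromethoxy in place of fluoro also depends on its partner, for with 3-hydroxyphenyl present it gives an at least 35-fold higher number from compound 2 to compound 4 (1.55 log units; beyond the scatter), again opposite to its step with 2-hydroxyphenyl present: the same change on two cores in this assay, an at least 3.3-fold lower number (0.52 log units; beyond the scatter) from compound 1 to compound 3 and an at least 35-fold higher number (1.55 log units; beyond the scatter) from compound 2 to compound 4, at least 110-fold (2.07 log units) apart, beyond the scatter of two such steps So the two changes cannot be treated as independent in these compounds, but the data do not show why, and compound 1 and compound 4 give limits rather than numbers, so these steps and gaps are minimum sizes only: the limit of > 50000 nM in this assay, at which 2 of the 4 values shown sit.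

The compounds shown leave open whether this reversal would also appear with a chloro or methoxy group in place of fluoro or trifluoromethoxy. They also leave open what an amine in place of the hydroxyl of the 3-hydroxyphenyl group would do on either core.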